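A few compounds are considered here, and "the series" means these few. Any claim that something is new, unique, unknown or untested is made for them only; others in the source may bear on it.

Compound 1, `CC/C=C\C/C=C\C/C=C\CCCCCCCc1cc(O)cc(O)c1`: 8700 nM.
Compound 2, `CC/C=C\C/C=C\C/C=C\CCCCCCCc1cc(OC(C)=O)cc(OC(C)=O)c1`: "not determined" (no result reported).

Among the compounds with values here, in a functional assay on MCF7 cells (Homo sapiens) for cytotoxicity (on this read-out higher numbers stand for weaker inhibition and lower numbers for stronger inhibition), compound 1 gives 8700 nM, and this is the only number in the set, so compound 1 stands alone as the reference point. Compound 2, the related structure `CC/C=C\C/C=C\C/C=C\CCCCCCCc1cc(OC(C)=O)cc(OC(C)=O)c1`, has "not determined" (no result reported) in this assay, so it offers no comparison. Compound 3, `CC/C=C\C[C@@H](O)CC/C=C\CCCCCCCc1cc(O)cc(O)c1`, has not yet been tested. It differs from compound 1 in a single place: a group of 8 heavy atoms (7 carbon, 1 oxygen; no ring) in place of a group of 7 heavy atoms (7 carbon; no ring), on a saturated chain carbon bound to a double-bonded chain carbon. Within the data shown here, no step between two measured compounds is available, so any forecast must rest on compound 1 alone. The change keeps the chain nearly as long but trades one of its double bonds for a hydroxyl bearing a defined stereocentre. The expected step of a 1.5-fold higher number from compound 1 to compound 3 (0.17 log units; within the scatter) is small, toward weaker inhibition, and may not exceed the usual scatter. Compound 3 is therefore estimated at 13000 nM, with a range from 4500 nM to 40000 nM.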

Compound 3, half-maximal inhibitory concentration: 22000 nM
For compound 3 the middle estimate is 1.7-fold (0.23 log units) below the measured one; the measured number falls inside the stated range.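

Within the data shown here, the first measured step at this place shows that the chain does not tolerate every change without effect: in this assay, putting the new hydroxyl-bearing group in place of hepta-1,4-dien-1-yl gives a 2.5-fold higher number from compound 1 to compound 3 (0.40 log units; beyond the scatter), a modest loss of strength that lies beyond the scatter. The shared core stays the same. The two compounds differ only on a saturated chain carbon bound to a double-bonded chain carbon. No measurement shown here explains the shift.

The step combines the loss of one double bond with the arrival of a hydroxyl and a defined stereocentre, so the compounds shown cannot separate these changes or reveal how the opposite arrangement at that stereocentre would compare. A methoxy group or an amine at this place would test whether other groups there give a similar step.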